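Urotensin-2 receptor agonists: para substituent on the cinnamamide ring

The source may hold more compounds than are shown below. What is called first, only, known or untested is meant among the compounds shown, and "the series" means these compounds.

Measured so far:
compound 1 `CN(C)CCC(NC(=O)/C=C/c1ccc(C(F)(F)F)cc1)c1ccc2ccccc2c1`: 117%
compound 2 `CN(C)CCC(NC(=O)/C=C/c1ccccc1)c1ccc(Cl)cc1`: 128%

Both compounds share an amide of a cinnamic acid with a basic side chain. In a functional assay on NIH3T3 cells for agonist activity at Urotensin-2 receptor (Homo sapiens), with a stated time of 5 days (on this read-out lower numbers stand for smaller maximal responses and higher numbers for larger maximal responses), compound 1 gives 117%, the lower of the two numbers; compound 2 gives 128%, and the gap between the two lies beyond the scatter. The two compounds differ in more than one place, so no single step can be read from them.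

Compound 3 `COc1ccc(/C=C/C(=O)NC(CCN(C)C)c2ccc3ccccc3c2)cc1` keeps the core of compound 1 and differs from it as follows: methoxy in place of trifluoromethyl on an aromatic carbon

Going by the values given here, no measured pair shows what a change of this kind does here, so the direction of the step is open. Since both measured compounds reach a large maximal response, the expectation for compound 3 in this assay is a step of a number 2 percentage points lower from compound 1 to compound 3 (within the scatter) that stays within the scatter, with no clear direction. Compound 3 is accordingly estimated at 115%, within a range from 90% to 135%.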

Compound 3, largest response reached (reported as efficacy), in percent of the reference or control that the assay uses: 106%
Compound 3: the middle estimate sits 9 percentage points above what was measured; measured number inside the range.
By their numbers in this assay, from the lowest: compound 3; then compound 1; then compound 2.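

In this assay, going by these compounds alone, the change from 4-(trifluoromethyl)phenyl to 4-methoxyphenyl gives a number 11 percentage points lower from compound 1 to compound 3 (beyond the scatter) and is the first single-place comparison. It shows that the group on this aromatic carbon, para to a large group, can shift the maximal response by a modest margin on the core of compound 1, while compound 3 still reaches 106% in this assay and so keeps a large response with methoxy in this place. No measured property of the two groups or of the two compounds bears on the step, so the data offer no explanation for it.

Going by these compounds, compound 2 differs from compound 1 and compound 3 in more than one place, so steps to it cannot be read, and it remains open whether the methoxy change would act in the same direction and to a similar extent on the core of compound 2. Also open, on these data alone, is how the maximal response would change with an amine, a carboxylic acid, a nitrile or a plain hydrogen on this same aromatic carbon, which would show whether trifluoromethyl and methoxy mark a wider trend at this position.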